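The source may report more compounds than this note shows. Statements on the series, on what has been measured and on what is new or still open speak of the compounds shown alone.

Measured compounds:
compound 1, `OC(CCn1nc2c(Br)c(Br)c(Br)c(Br)c2n1)c1ccc(F)cc1`, 0%;
compound 2, `C[C@@H](O)CCn1nc2c(Br)c(Br)c(Br)c(Br)c2n1`, 23%;
compound 3, `C[C@H](O)CCn1nc2c(Br)c(Br)c(Br)c(Br)c2n1`, 42%.

In a functional assay on CCRF-CEM cells (Homo sapiens) for antiproliferative activity, read by MTT assay, with a stated time of 48 h, tested at 50 uM (a higher number here means a weaker effect of the compound at the concentration tested, a lower number a stronger effect), compound 1 gives 0%, the lowest of the three numbers and therefore the strongest effect at the tested concentration; its nearest neighbour is compound 2, and compound 3 stands furthest from it. Among the measured compounds shown here, the only step between measured compounds that differ in one place is a number 19 percentage points higher from compound 2 to compound 3 (beyond the scatter), which rests on the fact that compounds 2 and 3 differ only in the configuration as drawn and says nothing about substitution on the aromatic ring.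

Compound 4, `OC(CCn1nc2c(Br)c(Br)c(Br)c(Br)c2n1)c1ccc(Br)cc1`, has not yet been measured. It differs from compound 1 by bromo in place of fluoro on an aromatic carbon. For the measured compounds named here, no measured step bears on this change, so there is no basis for expecting a move in either direction, and a step of a number 5 percentage points higher from compound 1 to compound 4 (within the scatter), within the scatter, is expected. Compound 4 is estimated at 5%, with a range from 0% to 25%.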

Compound 4, a percentage reported as activity, at one concentration (the size of the read-out at that concentration, not a potency): 0%
Estimate against measurement, compound 4: 5 percentage points above, within the range that was stated.
By their numbers in this assay, from the lowest: compounds 1 and 4 (each within the scatter of the next); then compound 2; then compound 3.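

In this assay, among the compounds shown here, going from 4-fluorophenyl to 4-bromophenyl gives no change at the digits printed from compound 1 to compound 4 (within the scatter), so this is the first sign that this position accepts either halogen without a visible loss of effect. The change is also the first one shown on the aromatic ring, since the earlier step concerned configuration alone, but a read-out at one concentration cannot show whether the two compounds differ in potency at lower concentrations. Nothing in the available evidence bears on why the two halogens read alike.

On these data alone, it remains open whether a methoxy group, an amine or a carboxylic acid at this position, or an unsubstituted phenyl ring, would keep the same read-out. As far as these compounds go, it is also open whether the configuration at the hydroxyl-bearing carbon matters once the aromatic ring is present.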